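The compounds below may be only part of what the source reports. "The series", "measured", "known", "first", "only" and "open" are said of these compounds alone.

Measured compounds:
- Compound 1, `C#CCn1cc(C(=O)NCCCOC(=O)CNC(=O)OC(C)(C)C)c(=O)c2cccnc21`: in a functional assay on HBL-100 cells (Homo sapiens) for cytotoxicity, read by MTT assay, with a stated time of 72 h (on this read-out lower numbers stand for stronger inhibition and higher numbers for weaker inhibition), compound 1 gives > 10000 nM, which is a limit of the assay rather than a number.
- Compound 2, `C#CCn1cc(C(=O)NCCCOC(=O)[C@H]2CCCN2C(=O)OC(C)(C)C)c(=O)c2ccc(Cl)nc21`: in this assay compound 2 gives 3700 nM.
- Compound 3, `C#CCn1cc(C(=O)NCCCOC(=O)[C@H](C)NC(=O)OC(C)(C)C)c(=O)c2ccc(Cl)nc21`: in this assay compound 3 gives 5400 nM.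

Compound 3 holds the highest of the two numbers shown, yet its only neighbour with a number is close: a 1.5-fold higher number from compound 2 to compound 3 (0.16 log units; within the scatter). For the measured compounds named here, the one remaining value, for compound 1, is a limit and cannot be ranked.

Compound 4, `C#CCn1cc(C(=O)N[C@@H](C)CCOC(=O)[C@H](C)NC(=O)OC(C)(C)C)c(=O)c2ccc(Cl)nc21`, is not yet measured. It differs from compound 3 in one place: methyl in place of hydrogen on a saturated chain carbon bound to an amide-type nitrogen and a saturated chain carbon. Going by the values given here, no measured step touches this part of the molecule; the only measured step, from compound 2 to compound 3, changes the group on the ester carbonyl and stays within the scatter. With nothing pointing in either direction, no step beyond the scatter is expected here, and the expected change is no change at the digits printed from compound 3 to compound 4 (within the scatter). Compound 4 is therefore estimated at 5400 nM in this assay, with a range from 2000 nM to 15000 nM.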

Compound 4, half-maximal inhibitory concentration: > 10000 nM
Compound 4: only a limit was reported (the forecaster's own chance of this, stated with the estimate: 25%); middle value at least 1.8-fold (0.26 log units) from the limit.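

Methyl in place of hydrogen on a saturated chain carbon bound to an amide-type nitrogen and a saturated chain carbon is the first change shown at this place, and it comes with an at least 1.8-fold higher number from compound 3 to compound 4 (0.26 log units; that floor lies within the scatter). In this assay compound 4 gives > 10000 nM, which is a limit of the assay and not a number. This step therefore has only a floor, so a small methyl change here could be minor or much larger, and the limit hides its true size: the limit of > 10000 nM in this assay, at which 2 of the 4 values shown sit.

Still open, on these data alone, is whether an ethyl group or a hydroxymethyl group on this carbon would give a measurable number, and whether the mirror-image arrangement of the methyl would behave the same way. As far as these compounds go, it is also open whether this methyl would have a similar effect alongside the 1-(tert-butoxycarbonyl)pyrrolidin-2-yl group of compound 2.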